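Closing a sulfonyl chain into a four-membered ring

The source may hold more compounds than are shown below. What is called first, only, known or untested is meant among the compounds shown, and "the series" means these compounds.

Of the compounds shown here, three sharing one core have been measured. Compound 1 `NS(=O)(=O)CC(=O)NCCSc1nonc1/C(=N/O)Nc1cccc(Br)c1` gives 8.1 nM in an assay for inhibition of Indoleamine 2,3-dioxygenase 1 (Homo sapiens), read by fluorescence, with a stated time of 24 h; a higher number here means a weaker inhibitor, a lower number a stronger inhibitor. Compound 2 `NS(=O)(=O)CC(=O)NCCSc1nonc1/C(=N/O)Nc1ccc(F)c(C(F)F)c1` gives 13 nM, with a 1.6-fold higher number from compound 1 to compound 2 (0.21 log units; within the scatter). Compound 3 `CS(=O)(=O)CC(=O)NCCSc1nonc1/C(=N/O)Nc1ccc(F)c(C(F)F)c1` gives 14 nM, with a 1.1-fold higher number from compound 2 to compound 3 (0.03 log units; within the scatter). All three numbers therefore lie within the usual scatter of one another, and compound 3 cannot be set apart from either neighbour on these data.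

Compound 4 `O=C(NCCSc1nonc1/C(=N/O)Nc1ccc(F)c(C(F)F)c1)C1CS(=O)(=O)C1` is not yet measured. It differs from compound 3 in one place: a group of 6 heavy atoms (3 carbon, 2 oxygen, 1 sulfur; one four-membered non-aromatic ring with 1 hetero atom) in place of a group of 5 heavy atoms (2 carbon, 2 oxygen, 1 sulfur; no ring), on a carbonyl carbon. The change sits on the carbonyl carbon whose other neighbour is the amide-type nitrogen, so the sulfonyl-bearing end of the chain is reshaped while the rest of the molecule is kept.

For the measured compounds named here, only one measured step touches this end of the molecule, the swap of methyl for amino on the sulfonyl sulfur between compound 2 and compound 3, and it stayed within the scatter. On that basis the step from compound 3 to compound 4 is expected to be small, a 1.1-fold higher number from compound 3 to compound 4 (0.03 log units; within the scatter), in no firm direction. Compound 4 is estimated at 15 nM, with a range from 6 nM to 40 nM.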

Compound 4, half-maximal inhibitory concentration: 13 nM
Compound 4: the middle estimate sits 1.2-fold (0.06 log units) above what was measured; low and high end bracket the measured number.
By their numbers in this assay, from the lowest: compounds 1, 2, 4 and 3 (each within the scatter of the next).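

In this assay the open (methylsulfonyl)methyl group gives way to the four-membered ring on the carbonyl carbon with a 1.1-fold lower number from compound 3 to compound 4 (0.03 log units; within the scatter), so this end of the chain can take a ring without leaving the scatter. Set against the amino-bearing chain, the ring gives no change at the digits printed from compound 2 to compound 4 (within the scatter), which extends the earlier finding from a swap on the sulfonyl sulfur alone to the exchange of a whole group. Nothing available offers a reason for this flat result.

Every compound shown keeps a sulfonyl group at this end, so it remains open whether a carboxylic acid, an amine or a plain cyclobutane ring could stand in its place. A longer chain carrying the sulfonyl group is also untested in the compounds shown.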